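The compounds below may be only part of what the source reports. "The series", "measured", "known", "first", "only" and "open" are said of these compounds alone.

Working notes on the series, cytotoxicity read-out. In an ADME assay on HepG2 2.2.15 cells (Homo sapiens) for cytotoxicity, read by MTT assay, with a stated time of 8 days (on this read-out lower numbers stand for higher toxicity in this test and higher numbers for lower toxicity in this test), compound 1 `N#Cc1ccc(Cn2nc(-c3cc(Cl)c(NCCO)nc3F)c3ccccc3c2=O)cc1` gives 32100 nM, the lower of the two actual numbers available. Compound 2 `Cc1cc(-c2ccc(F)nc2F)cn(Cc2ccc(Cl)cc2)c1=O` gives 90800 nM, a gap from compound 1 that lies beyond the scatter. Compound 3 `Cn1cc(-c2ccc(F)nc2F)nc(Cc2ccc(Cl)cc2)c1=O` returns only a limit, > 100000 nM, and not a number.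

Compound 4 `COC(=O)CCNc1nc(F)c(-c2nn(Cc3ccc(C#N)cc3)c(=O)c3ccccc23)cc1Cl` keeps the core of compound 1 and changes one group: methoxycarbonyl in place of hydroxy on a saturated chain carbon, two bonds along the chain from a nitrogen on an aromatic ring. The new group is methoxycarbonyl in place of hydroxy, on a saturated chain carbon, two bonds along the chain from a nitrogen on an aromatic ring. For the measured compounds named here, neither compound 2 nor compound 3 carries the 2-hydroxyethyl group, and no measured pair tests this change.

The expectation therefore starts from compound 1 at 32100 nM, and no step beyond the scatter is expected in this assay, in either direction. The estimated step is a 1.1-fold lower number from compound 1 to compound 4 (0.03 log units; within the scatter), which is expected to stay within the scatter. The range is kept wide because it rests on a single close analogue. For compound 4 the estimated value in this assay is 30000 nM, with an expected range of 11000 nM to 85000 nM.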

Compound 4, half-maximal cytotoxic concentration: > 100000 nM
Compound 4 gave a limit, no number; the forecaster's own chance of this, stated with the estimate: 12%; at least 3.3-fold (0.52 log units) between middle value and limit.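

For the compounds shown here, the change from hydroxy to methoxycarbonyl, on a saturated chain carbon, two bonds along the chain from a nitrogen on an aromatic ring, is the first change that can be read at one place. In this assay it gives an at least 3.1-fold higher number from compound 1 to compound 4 (0.49 log units; beyond the scatter). This position therefore registers on this read-out: with the rest of compound 1 kept, going from (2-hydroxyethyl)amino to (2-(methoxycarbonyl)ethyl)amino moves the result towards lower toxicity in this test, and the size of the step is only a lower bound, with the result for compound 4 sitting at the top of the measurable range: the limit of > 100000 nM in this assay, at which 2 of the 4 values shown sit.

The change swaps hydroxy for methoxycarbonyl in one move, so the compounds shown do not separate the loss of the hydroxy from the arrival of the methoxycarbonyl; a methoxy group or a carboxylic acid at the same place, or a longer chain carrying the hydroxy, would pull the two apart. Also open, from the compounds shown here alone, are how far past the limit compound 4 lies and whether the same change on another core gives a step of this kind.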